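Side-chain steps and an estimate for compound 4

The compounds below may be only part of what the source reports. "The series", "measured", "known", "first", "only" and "open" are said of these compounds alone.

compound 1 `COC(C)CO[C@H](CC=C(C)C)C1=CC(=O)c2c(O)ccc(O)c2C1=O`: 16600 nM
compound 2 `CC(=O)OCCC(=O)O[C@H](CC=C(C)C)C1=CC(=O)c2c(O)ccc(O)c2C1=O`: 15700 nM
compound 3 `CCC(CO[C@H](CC=C(C)C)C1=CC(=O)c2c(O)ccc(O)c2C1=O)OC(C)=O`: 25400 nM

In a functional assay on DU-145 cells (Homo sapiens) for cytotoxicity, read by MTT assay (on this read-out lower numbers stand for stronger inhibition and higher numbers for weaker inhibition), compound 3 stands within the scatter of both other compounds (a 1.5-fold higher number from compound 1 to compound 3 (0.18 log units; within the scatter); a 1.6-fold higher number from compound 2 to compound 3 (0.21 log units; within the scatter)). The third step (a 1.1-fold lower number from compound 1 to compound 2 (0.02 log units; within the scatter)) also stays within the scatter. Compound 4 `CC(C)=CC[C@@H](OCCO)C1=CC(=O)c2c(O)ccc(O)c2C1=O` has hydroxymethyl in place of 1-acetoxypropyl on a saturated chain carbon bound to an oxygen on a saturated carbon. All three measured steps alter this same side chain, but none places hydroxymethyl there, so they are only a loose guide. No step beyond the scatter is therefore expected in this assay, and the range is kept wide. The expected step is small (a 1.4-fold lower number from compound 3 to compound 4 (0.15 log units; within the scatter)). For compound 4 the estimated value is 18000 nM (expected range 7000 nM to 40000 nM).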

Compound 4, half-maximal inhibitory concentration: 9900 nM
The estimate for compound 4 lay 1.8-fold (0.26 log units) above the measured number; the range from low to high includes it.
By their numbers in this assay, from the lowest: compounds 4, 2, 1 and 3 (each within the scatter of the next, the first and the last beyond it).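

In this assay, among the compounds shown here, compound 4 gives the first step beyond the scatter, a 2.6-fold lower number from compound 3 to compound 4 (0.41 log units; beyond the scatter), with hydroxymethyl in place of 1-acetoxypropyl on a saturated chain carbon bound to an oxygen on a saturated carbon. The other two steps stay within the scatter (a 1.6-fold lower number from compound 2 to compound 4 (0.20 log units; within the scatter)) (a 1.7-fold lower number from compound 1 to compound 4 (0.22 log units; within the scatter)), so the separation holds against compound 3 only. Nothing available accounts for this step.

The change from 2-acetoxybutyl to 2-hydroxyethyl alters both the chain length and the end group, and a 2-hydroxybutyl or 2-acetoxyethyl group would separate the two. Going by these compounds, an amine or a carboxylic acid in the same place also remains open.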